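This account rests on a few compounds, and the source may have more. Where it says the series, first, only, none or still open, it means among the compounds named here.

Working notes on the series. Within the data shown here, compound 1 `CCCCCCc1cc2cn(Cc3cn(Cc4ccccc4)nn3)c(=O)nc2o1` carries a hexyl group on the shared core, and in a functional assay on A549 cells (Homo sapiens) for antiproliferative activity, read by MTT assay, with a stated time of 72 h (on this read-out higher numbers stand for weaker inhibition and lower numbers for stronger inhibition), compound 1 gives 51000 nM, the highest of the two numbers measured so far. Among the measured compounds shown here, compound 2 `O=c1nc2oc(C3CC3)c(C#CC3CC3)c2cn1Cc1cn(Cc2ccccc2)nn1` differs from compound 1 in more than one place, so no single step joins them; in this assay compound 2 gives 4810 nM, a lower number than compound 1 by a margin beyond the scatter. Compound 3 `CCCCCCC#Cc1c(CCCCCC)oc2nc(=O)n(Cc3cn(Cc4ccccc4)nn3)cc12` is the next candidate. It differs from compound 1 by oct-1-yn-1-yl in place of hydrogen on an aromatic carbon. For the measured compounds named here, no measured step isolates such a change, and the only guide is that compound 2, which also bears an alkynyl substituent on its core, sits well below compound 1. A step from compound 1 to compound 3 toward stronger inhibition is therefore expected, of moderate size and beyond the scatter. Compound 3 is expected to give 9000 nM, with a range from 2500 nM to 30000 nM. The expected step of a 5.7-fold lower number from compound 1 to compound 3 (0.75 log units; beyond the scatter) is an estimate, not a measurement.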

Compound 3, half-maximal inhibitory concentration: 21900 nM
The estimate for compound 3 lay 2.4-fold (0.39 log units) below the measured number; the range from low to high includes it.
By their numbers in this assay, from the lowest: compound 2; then compound 3; then compound 1.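

Among these compounds, at this aromatic carbon, next to the ring atom that bears a hexyl group, the first single-place comparison is now available: in this assay, oct-1-yn-1-yl in place of hydrogen gives a 2.3-fold lower number from compound 1 to compound 3 (0.37 log units; beyond the scatter), a modest change beyond the scatter. The position therefore accepts this unbranched chain of 8 carbon atoms with its triple bond, and inhibition becomes stronger rather than weaker, although only by a modest margin. No measured data on the properties of this group accompany the step, so the result cannot be explained from the information available.

The compounds shown leave open whether the triple bond or the chain itself accounts for the step, as a saturated octyl chain or a shorter alkynyl chain at this carbon would show. They also leave open how an amine at the end of the chain would change the number, and whether the step would hold with a group other than hexyl on the neighbouring ring atom.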